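The source may hold more compounds than are shown below. What is called first, only, known or untested is meant among the compounds shown, and "the series" means these compounds.

Measured so far in a functional assay on DU-145 cells (Homo sapiens) for inhibition, read by trypan blue exclusion, with a stated time of 72 h; a higher number here means a weaker inhibitor, a lower number a stronger inhibitor:
- compound 1 `Cn1c(=O)c(S(=O)(=O)c2ccc(F)cc2F)cc2cnc(Nc3ccc4occc4c3)nc21`: 15000 nM
- compound 2 `Cn1ccc2cc(Nc3ncc4cc(S(=O)(=O)c5ccc(F)cc5F)c(=O)n(C)c4n3)ccc21`: 750 nM
- compound 3 `Cn1c(=O)c(S(=O)(=O)c2ccc(F)cc2F)cc2cnc(Nc3ccc4[nH]ncc4c3)nc21`: 30000 nM

Compound 3 stands with the highest number of the three. Its nearest neighbour is compound 1 a 2.0-fold higher number from compound 1 to compound 3 (0.30 log units; within the scatter), and its furthest is compound 2 a 40-fold higher number from compound 2 to compound 3 (1.60 log units; beyond the scatter). Compound 4 `Cc1cc2cc(Nc3ncc4cc(S(=O)(=O)c5ccc(F)cc5F)c(=O)n(C)c4n3)ccc2[nH]1` is not yet measured; it differs from compound 3 in one place: 2-methyl-1H-indol-5-yl in place of 1H-indazol-5-yl on a nitrogen on an aromatic ring.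

For the measured compounds named here, two measured steps bear on this change, both at the same nitrogen. Swapping 1-methyl-1H-indol-5-yl for 1H-indazol-5-yl gave a 40-fold higher number from compound 2 to compound 3 (1.60 log units; beyond the scatter), and swapping 1-benzofuran-5-yl for 1-methyl-1H-indol-5-yl gave a 20-fold lower number from compound 1 to compound 2 (1.30 log units; beyond the scatter). The five-membered ring of compound 4 is again an indole, though with the methyl on carbon and the hydrogen-bond donor retained, so a large step toward a lower number is expected, likely short of fully matching compound 2. For compound 4 the expected step is a 20-fold lower number from compound 3 to compound 4 (1.30 log units; beyond the scatter). Compound 4 is therefore estimated at 1500 nM, within 400 nM to 8000 nM.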

Compound 4, half-maximal inhibitory concentration: 750 nM
The estimate for compound 4 lay 2.0-fold (0.30 log units) above the measured number; the range from low to high includes it.
By their numbers in this assay, from the lowest: compounds 2 and 4 (each within the scatter of the next); then compounds 1 and 3 (each within the scatter of the next).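

The 2-methyl-1H-indol-5-yl group restores the low number (from 1H-indazol-5-yl: a 40-fold lower number from compound 3 to compound 4 (1.60 log units; beyond the scatter)), and it also separates from 1-benzofuran-5-yl (a 20-fold lower number from compound 1 to compound 4 (1.30 log units; beyond the scatter)). Moving the methyl from the indole nitrogen to carbon leaves the number in place (no change at the digits printed from compound 2 to compound 4 (within the scatter)), so a hydrogen-bond donor on the group is neither required, as compound 2 shows, nor sufficient, as compound 3 shows. No supporting data explain these differences.

Open, from the compounds shown here alone, is whether the unsubstituted 1H-indol-5-yl group needs a methyl at all. Also open, going by these compounds, is how a longer chain or an amine in place of that methyl would read.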